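Amine nitrogen substituent variation on the shared core

The source may hold more compounds than are shown below. What is called first, only, known or untested is meant among the compounds shown, and "the series" means these compounds.

Measured in a functional assay on EA.hy 926 cells (Homo sapiens), read by fluorescence, tested at 1 uM; on this read-out higher numbers stand for a stronger effect at the one concentration tested and lower numbers for a weaker effect:
compound 1 `COc1cc(/C=C/C(=O)/C=C(/C=C/c2ccc(OC(C)=O)c(OC)c2)NC2CCCCC2)ccc1OC(C)=O`: 101%
compound 2 `COc1cc(/C=C/C(=O)/C=C(/C=C/c2ccc(OC(C)=O)c(OC)c2)NCC(C)C)ccc1OC(C)=O`: 104%

For the measured compounds named here, compound 2 holds the higher of the two numbers so far, yet the step of a number 3 percentage points higher from compound 1 to compound 2 (within the scatter) lies within the scatter, so compound 1 and compound 2 cannot be told apart on this read-out; both sit at essentially full effect at the one concentration tested.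

The next compound, compound 3 `CCC(C)NC(=C\C(=O)/C=C/c1ccc(OC(C)=O)c(OC)c1)/C=C/c1ccc(OC(C)=O)c(OC)c1`, keeps every atom of compound 2 and moves only the branch of the four-carbon chain on the amine nitrogen: sec-butyl in place of isobutyl on an amine nitrogen.

Going by the values given here, only one measured step bears on this change, the exchange of the group on the same amine nitrogen from compound 1 to compound 2, a number 3 percentage points higher from compound 1 to compound 2 (within the scatter), which stayed within the scatter. A second rearrangement of a small hydrocarbon group at that nitrogen is therefore expected to give a step of a number 2 percentage points lower from compound 2 to compound 3 (within the scatter), no change beyond the scatter, with the read-out remaining near full effect.

For compound 3 the estimated value is 102%, expected to fall between 92% and 112%.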

Compound 3, a percentage reported as activity, at one concentration (the size of the read-out at that concentration, not a potency): 68%
Beside the measured number, compound 3's estimate is 34 percentage points above it, and the stated range ends above it.
By their numbers in this assay, from the lowest: compound 3; then compounds 1 and 2 (each within the scatter of the next).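

The amine nitrogen is less forgiving than the first pair suggested: in this assay, exchanging isobutyl for sec-butyl, with the atoms of the group unchanged and only their connection altered, gives a number 36 percentage points lower from compound 2 to compound 3 (beyond the scatter), so the read-out at this position depends on how the hydrocarbon group is joined and not only on what it contains. Cyclohexyl also stands well clear of sec-butyl, with a number 33 percentage points lower from compound 1 to compound 3 (beyond the scatter), which means that compound 1 and compound 2 define a level of effect that this position does not hold for every small hydrocarbon group, and that the heavy-atom count, identical for isobutyl and sec-butyl, does not settle the outcome. Nothing available explains why sec-butyl behaves differently from isobutyl at this nitrogen.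

The compounds shown leave open how other groups on this nitrogen would read, such as tert-butyl, an unbranched butyl chain or cyclopentyl, and so whether sec-butyl is an isolated case or part of a wider trend. For the compounds shown here, with a single concentration behind each number, they also show only that compound 3 has a weaker effect than compound 2 at that concentration, and leave open how the two would compare at any other concentration.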